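The compounds below may be only part of what the source reports. "The series", "measured", "known", "first", "only" and "open" are said of these compounds alone.

Compound 1 `O=C(Nc1cccc(-n2cc(-c3ccncc3)c(-c3ccc(Cl)c(O)c3)n2)c1)Nc1ccc(Cl)c(Cl)c1` is read in a functional assay on MCF7 cells (Homo sapiens) for inhibition, read by sulforhodamine B assay, with a stated time of 48 h; a lower number here means a stronger inhibitor of growth, a higher number a weaker inhibitor of growth. In this assay compound 1 gives > 32500 nM, which is a limit of the assay and not a number. Compound 2 `COc1cc(-c2nn(-c3cccc(NC(=O)c4ccc(Cl)c(C(F)(F)F)c4)c3)cc2-c2ccncc2)ccc1Cl` gives > 32500 nM, again a limit. Compound 3 `COc1cc(-c2nn(-c3cccc(NC(=O)c4ccccc4)c3)cc2-c2ccncc2)ccc1Cl` gives > 100000 nM, also a limit. Among the compounds with values here, the single measured change in the set, a step that the two limits leave unreadable from compound 2 to compound 3, joins two limits, so its size cannot be read. Compound 1 therefore stands on a limit only; the two further values shown are limits as well, sitting at the limit of > 32500 nM in this assay, at which 2 of the 3 values shown sit, and at the limit of > 100000 nM in this assay, at which 1 of the 3 values shown sits.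

Compound 4 `O=C(Nc1cccc(-n2cc(-c3ccncc3)c(-c3ccc(Cl)c(O)c3)n2)c1)Nc1cccc(C(F)(F)F)c1` differs from compound 1 by 3-(trifluoromethyl)phenyl in place of 3,4-dichlorophenyl on an amide-type nitrogen. Within the data shown here, no measured change touches an amide-type nitrogen, so none of the measured steps bears on this one, and the only measured step is itself unreadable. With every value shown being a limit, compound 4 is expected in this assay to show no step beyond the scatter, a step that the limit leaves unreadable from compound 1 to compound 4. Compound 4 is accordingly estimated at 40000 nM, within 15000 nM to 150000 nM, a further limit being the most likely outcome.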

Compound 4, concentration for total growth inhibition: > 32500 nM
Compound 4 ended at the assay's limit; the forecaster's own chance of this, stated with the estimate: 80%; the middle value does not contradict the limit.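

Compound 4 gives > 32500 nM, a limit of the assay and not a number. Within the data shown here, compound 1 gives > 32500 nM, also a limit, so no step between these two compounds can be read. Still open is whether any compound shown reaches a readable concentration for total growth inhibition, and whether 3-(trifluoromethyl)phenyl in place of 3,4-dichlorophenyl changes that concentration.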